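Hydantoin hydroxamates: chain substituent at the quaternary carbon

The source may report more compounds than this note shows. Statements on the series, on what has been measured and on what is new or still open speak of the compounds shown alone.

Measured so far in an assay on isolated protein for inhibition of protein deacetylase HDAC6 (Homo sapiens), read by fluorescence, with stated times of 10 min and 2 h; a higher number here means a weaker inhibitor, a lower number a stronger inhibitor:
- compound 1, `CCCC1(c2ccccc2)NC(=O)N(Cc2ccc(C(=O)NO)cc2)C1=O`, gives 50.9 nM
- compound 2, `Cc1ccc(CC2(c3ccccc3)NC(=O)N(Cc3ccc(C(=O)NO)cc3)C2=O)cc1`, gives 82.4 nM
- compound 3, `CC(C)(C)c1ccc(CC2(c3ccccc3)NC(=O)N(Cc3ccc(C(=O)NO)cc3)C2=O)cc1`, gives 115 nM

Compound 3 carries the highest number of the three; the gap to compound 2 is within the scatter, and only the gap to compound 1 is beyond it. The steps that reach compound 3 are a 2.3-fold higher number from compound 1 to compound 3 (0.35 log units; beyond the scatter) and a 1.4-fold higher number from compound 2 to compound 3 (0.14 log units; within the scatter), with a 1.6-fold higher number from compound 1 to compound 2 (0.21 log units; within the scatter) lying between.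

Compound 4 is `O=C(NO)c1ccc(CN2C(=O)NC(CCc3ccccc3)(c3ccccc3)C2=O)cc1`. Its change from compound 3 is benzyl in place of 4-(tert-butyl)phenyl on a saturated chain carbon bound to a saturated ring carbon. Two pieces of evidence bear on this: removal of the tert-butyl reads in reverse of a 1.4-fold higher number from compound 2 to compound 3 (0.14 log units; within the scatter), and a phenyl-bearing chain in place of the shorter chain reads like a 1.6-fold higher number from compound 1 to compound 2 (0.21 log units; within the scatter). Both are within the scatter, so for compound 4 the step of a 1.5-fold lower number from compound 3 to compound 4 (0.19 log units; within the scatter) is expected, a slightly lower number, with a modest size at most. Compound 4 is therefore estimated at 75 nM in this assay, with a plausible range from 35 nM to 160 nM.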

Compound 4, half-maximal inhibitory concentration: 24.7 nM
Compound 4: the middle estimate sits 3.0-fold (0.48 log units) above what was measured; measured number below the stated range.
By their numbers in this assay, from the lowest: compound 4; then compounds 1, 2 and 3 (each within the scatter of the next, the first and the last beyond it).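

In this assay, among the compounds shown here, a terminal phenyl on the chain proves compatible with the strongest inhibition of the four compounds: phenyl in place of methyl on a saturated chain carbon, two bonds along the chain from a saturated ring carbon, gives a 2.1-fold lower number from compound 1 to compound 4 (0.31 log units; beyond the scatter) and is the first change to move below the shorter chain beyond the scatter. Aryl-bearing chains at this position do not behave alike, since phenethyl in place of 4-(tert-butyl)benzyl gives a 4.7-fold lower number from compound 3 to compound 4 (0.67 log units; beyond the scatter) and the corresponding change from the 4-methylbenzyl chain gives a 3.3-fold lower number from compound 2 to compound 4 (0.52 log units; beyond the scatter) as its step. No supporting data bear on why phenethyl differs from the substituted benzyl chains.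

Those two steps change chain length and ring substitution together, and an unsubstituted benzyl chain would be needed to separate them. As far as these compounds go, whether the trend continues to a 3-phenylpropyl chain, or tolerates an amine on the terminal phenyl, remains open.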